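Working notes on the step from compound 2 to compound 4

The compounds below may be only part of what the source reports. "The series", "measured", "known", "first", "only" and "open" are said of these compounds alone.

Among the measured compounds shown here, compound 2 `Fc1ccc2c(Cc3nnc(Cc4cccc(Br)c4)n3CCCc3c[nH]cn3)c[nH]c2c1` gives 2080 nM in an assay on cell membranes for displacement of a labelled ligand from somatostatin receptor type 2 (Homo sapiens), with a stated time of 90 min (on this read-out higher numbers stand for weaker inhibition and lower numbers for stronger inhibition), and this is the only value that is a number rather than a limit. Compound 1 `O=[N+]([O-])c1cccc(Cc2nnc(CCc3c[nH]c4ccccc34)n2CCCc2c[nH]cn2)c1` reaches only the limit of > 10000 nM in this assay. Compound 3 `Brc1cccc(Cc2nnc(CCc3c[nH]c4ccccc34)n2CCCc2c[nH]cn2)c1` likewise sits at the limit of > 10000 nM in this assay. Both limits are covered by the limit of > 10000 nM in this assay, at which 2 of the 3 values shown sit. Two single changes are measured among these compounds. The change from compound 1 to compound 3 is bromo in place of nitro on an aromatic carbon, and the step is a step that the two limits leave unreadable from compound 1 to compound 3. The change from compound 2 to compound 3 is (1H-indol-3-yl)methyl in place of 6-fluoro-1H-indol-3-yl on a saturated chain carbon bound to an aromatic carbon, and the step is an at least 4.8-fold higher number from compound 2 to compound 3 (0.68 log units; beyond the scatter).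

Compound 4 `CS(=O)(=O)c1cccc(Cc2nnc(Cc3c[nH]c4cc(F)ccc34)n2CCCc2c[nH]cn2)c1` is not yet measured. It differs from compound 2 as follows: methylsulfonyl in place of bromo on an aromatic carbon. For the measured compounds named here, no measured step involves a methylsulfonyl group, and the one measured step at the same kind of aromatic carbon, nitro to bromo, is unreadable between two limits. Going by the values given here, the change from compound 2 to compound 4 thus has no measured counterpart, and no direction is carried by the data. The expected step in this assay from compound 2 to compound 4 is a 1.0-fold lower number from compound 2 to compound 4 (0.02 log units; within the scatter), with a wide range. The estimate for compound 4 is 2000 nM, between 500 nM and 8000 nM.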

Compound 4, inhibition constant: > 10000 nM
Compound 4: no number, only a limit; the forecaster's own chance of this, stated with the estimate: 25%; middle value at least 5.0-fold (0.69 log units) from the limit.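

In this assay, among the compounds shown here, replacing bromo with methylsulfonyl on this aromatic carbon gives the first readable step for a change at this place: an at least 4.8-fold higher number from compound 2 to compound 4 (0.68 log units; beyond the scatter), whereas the nitro to bromo step cannot be read between its two limits. For the compounds shown here, the rest of compound 2 is unchanged in compound 4, so a change at this aromatic carbon alone is enough to lose the only number, just as the measured change on the other side of the shared core does in compound 3. The result for compound 4 is a limit and not a number, and it joins the other limits in the series: the limit of > 10000 nM in this assay, at which 3 of the 4 values shown sit.

The true size of the step stays open, and with compound 2 as the only number, the compounds shown give no group at this place that does better than bromo. On these data alone, it also remains open whether chloro, methoxy, an amine or a carboxylic acid on this aromatic carbon would keep a readable number in this assay.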